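A few compounds are considered here, and "the series" means these few. Any claim that something is new, unique, unknown or untested is made for them only; others in the source may bear on it.

Two compounds of this series have numbers in a functional assay on the whole organism for inhibition, with Rattus norvegicus as the target; on this read-out lower numbers stand for an effect already at smaller amounts and higher numbers for an effect only at larger amounts of compound. Compound 1 `CCc1cc(OCc2ccc(-c3ccccc3-c3nn[nH]n3)cc2)c(I)c(CC)n1` gives 0.44 mg/kg in this assay. Compound 2 `Cc1cc(NCc2ccc(-c3ccccc3-c3nn[nH]n3)cc2)c(I)c(C)n1` gives 0.05 mg/kg in this assay, the lowest of the two numbers; the gap to compound 1 lies beyond the scatter. These two compounds differ in more than one place, so no single change can be tied to that gap.

Compound 3 `Cc1cc(NCc2ccc(-c3ccccc3-c3nn[nH]n3)cc2)c(Cl)c(C)n1` has not yet been measured in this assay. It differs from compound 2 in one place: chloro in place of iodo on an aromatic carbon. For the measured compounds named here, no measured pair shows this exchange, so the size of the step from compound 2 to compound 3 in this assay is not known from the data. A small step toward a higher number is expected, a 2.4-fold higher number from compound 2 to compound 3 (0.38 log units; beyond the scatter), close to the edge of the scatter. Compound 3 is estimated at 0.12 mg/kg in this assay, with a range from 0.04 mg/kg to 0.4 mg/kg.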

Compound 3, dose for half-maximal effect: 0.03 mg/kg
Estimate against measurement, compound 3: 4.0-fold (0.60 log units) above; the measured number lies below the stated range.
By their numbers in this assay, from the lowest: compounds 3 and 2 (each within the scatter of the next); then compound 1.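

In this assay, chloro in place of iodo on this aromatic carbon, ortho to a large group and to a methyl group, gives a 1.7-fold lower number from compound 2 to compound 3 (0.22 log units; within the scatter), so the two halogens are not told apart here. For the compounds shown here, this is the first single change that can be read, and it shows that the iodo group is not needed at this position for a number at this level. The data available offer no explanation for this result at this position.

Going by these compounds, whether fluoro, a bare hydrogen, a methoxy group or a nitrile would hold the number at this carbon remains open. Also open, on these data alone, are the separate contributions of the ethyl groups and the ether linkage of compound 1, which differs from compound 2 in more than one place.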